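The source may report more compounds than this note shows. Statements on the series, on what has been measured and on what is new or still open speak of the compounds shown alone.

Compound 1 `CC(=O)Nc1ccc(-c2cc(=O)c3ccc(OC(C)=O)cc3o2)cc1`: 19.2 ug/mL
Compound 2 `COc1cc(-c2cc(=O)c3ccc(O)cc3o2)cc(OC)c1OC`: > 25 ug/mL

In a functional assay on MCF7 cells (Homo sapiens) for cytotoxicity, read by MTT assay, with a stated time of 6 days (a higher number here means that more compound is needed for the effect, a lower number that less compound is needed), compound 1 gives a measured number, 19.2 ug/mL. Compound 2 has only a limit, > 25 ug/mL, and not a number. Compound 3 `COc1cc(-c2cc(=O)c3ccc(O)c(O)c3o2)cc(OC)c1OC` differs from compound 2 in one place: hydroxy in place of hydrogen on an aromatic carbon. The new hydroxy sits ortho to a hydroxy group. Going by the values given here, no measured pair shows what such a change does in this assay. A small move towards less compound needed is expected, perhaps none beyond the scatter, and the estimated step is an at least 1.2-fold lower number from compound 2 to compound 3 (0.09 log units; that floor lies within the scatter). The expected value for compound 3 is 20 ug/mL, within an estimated range of 9 ug/mL to 35 ug/mL.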

Compound 3, concentration for half-maximal effect: 1.11 ug/mL
Compound 3: the middle estimate sits 18-fold (1.26 log units) above what was measured; the whole stated range lies above it.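

Adding one hydroxy ortho to a hydroxy group gives an at least 22-fold lower number from compound 2 to compound 3 (1.35 log units; beyond the scatter) in this assay. This position is therefore far from silent: a change of a single heavy atom here moves the result well beyond the scatter. That size is only a floor, since compound 2 has a limit and not a number: the limit of > 25 ug/mL in this assay, at which 1 of the 3 values shown sits.

From the compounds shown here alone, whether an amine or a fluorine at this position would do the same stays open. So does whether the neighbouring hydroxy group is needed for the gain.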